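This account rests on a few compounds, and the source may have more. Where it says the series, first, only, none or still open, it means among the compounds named here.

Measured so far:
compound 1 `O=C1C(=O)N(Cc2ccc(Cl)nc2)c2ccc(OC(F)(F)F)cc21` — 2400 nM
compound 2 `O=C1C(=O)N(Cc2ccc(-c3cccnc3)cn2)c2ccc(OC(F)(F)F)cc21` — limit only, > 30000 nM

Going by the values given here, in a functional assay on CHO cells for positive allosteric modulation of muscarinic acetylcholine receptor M5 (Homo sapiens), read by FLIPR and calcium flux, with a stated time of 1 h (on this read-out lower numbers stand for an effect already at smaller amounts and higher numbers for an effect only at larger amounts of compound), compound 1 gives 2400 nM and is the only entry with a number. Compound 2 reaches only a limit in this assay, namely > 30000 nM; see (the limit of > 30000 nM in this assay, at which 1 of the 2 values shown sits). Compound 3 `O=C1C(=O)N(Cc2ccc(-c3cccnc3)nc2)c2ccc(OC(F)(F)F)cc21` differs from compound 1 by pyridin-3-yl in place of chloro on an aromatic carbon. Among the compounds with values here, no measured step covers such a change here, so the expectation rests on compound 1 alone; a loss beyond the usual scatter is expected, a 5.0-fold higher number from compound 1 to compound 3 (0.70 log units; beyond the scatter). Compound 3 is therefore estimated at 12000 nM, with a range from 3000 nM to 40000 nM.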

Compound 3, half-maximal effective concentration: 4000 nM
Estimate against measurement, compound 3: 3.0-fold (0.48 log units) above, within the range that was stated.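

In this assay, pyridin-3-yl in place of chloro on an aromatic carbon, next to the ring nitrogen, gives a 1.7-fold higher number from compound 1 to compound 3 (0.22 log units; within the scatter). This position therefore accepts an added six-membered aromatic ring without a change beyond the scatter. Compound 2, which also carries pyridin-3-yl, gives only a limit of the assay: the limit of > 30000 nM in this assay, at which 1 of the 3 values shown sits.

Still open, from the compounds shown here alone, is whether phenyl, with no ring nitrogen, fits this position as pyridin-3-yl does. Also open, going by these compounds, is how an amine or a carboxylic acid here would compare with chloro.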